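Swapping Hydroxy for Methyl on a Plasma-Labile Ester

This account rests on a few compounds, and the source may have more. Where it says the series, first, only, none or still open, it means among the compounds named here.

Compound 1 `CC(=O)Oc1ccccc1C(=O)O[C@H]1CO[C@H]2[C@@H]1OC[C@H]2OC(=O)c1ccc(O)cc1` carries two ester-linked aromatic groups on a shared core, one of them a (4-hydroxyphenyl)carbonyl. In an ADME assay on a cell-free system (plasma, Homo sapiens) for metabolic stability, with Plasma (Rattus norvegicus) as the target, read by HPLC, at pH 7.4 (on this read-out lower numbers stand for a shorter-lived compound and higher numbers for a longer-lived compound), compound 1 gives 0.0198 h. Compound 2 `CCCCC(=O)O[C@@H]1CO[C@H]2[C@@H]1OC[C@@H]2OC(=O)c1ccccc1OC(C)=O`, with butyl in place of 4-hydroxyphenyl on that carbonyl carbon, gives 0.0198 h in this assay, and no change at the digits printed from compound 1 to compound 2 (within the scatter). Compound 3 `CC(=O)Oc1ccccc1C(=O)O[C@H]1CO[C@H]2[C@@H]1OC[C@H]2OC(=O)c1cccc(C)c1`, with 3-methylphenyl on the carbonyl carbon, gives 0.165 h; here an 8.3-fold higher number from compound 1 to compound 3 (0.92 log units; beyond the scatter), and likewise an 8.3-fold higher number from compound 2 to compound 3 (0.92 log units; beyond the scatter). Compound 1 thus sits level with compound 2 at the bottom of the three numbers, and only compound 3 stands clearly apart.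

Compound 4 `CC(=O)Oc1ccccc1C(=O)O[C@H]1CO[C@H]2[C@@H]1OC[C@H]2OC(=O)c1ccc(C)cc1` is not yet measured. It differs from compound 1 in one place: methyl in place of hydroxy on an aromatic carbon. For the measured compounds named here, the step that bears on this is the one to compound 3, where a methyl-bearing ring replaced the hydroxy-bearing ring and gave an 8.3-fold higher number from compound 1 to compound 3 (0.92 log units; beyond the scatter); compound 4 carries that ring as 4-methylphenyl rather than 3-methylphenyl. For compound 4 a rise of comparable size is therefore expected, a 6.1-fold higher number from compound 1 to compound 4 (0.78 log units; beyond the scatter), because compound 3 reached 0.165 h with a closely related change. The estimate for compound 4 is 0.12 h, with a range from 0.04 h to 0.35 h.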

Compound 4, half-life: 0.105 h
Compound 4: the middle estimate sits 1.1-fold (0.06 log units) above what was measured; low and high end bracket the measured number.
By their numbers in this assay, from the lowest: compounds 1 and 2 (each within the scatter of the next); then compounds 4 and 3 (each within the scatter of the next).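

In this assay, the change from hydroxy to methyl at this one place on the ring, para to a large group, gives a 5.3-fold higher number from compound 1 to compound 4 (0.72 log units; beyond the scatter) and shows that the higher number does not depend on moving the ring substituent, as the change to compound 3 also did. Placement of the methyl is not separated here, since 4-methylphenyl in place of 3-methylphenyl gives a 1.6-fold lower number from compound 3 to compound 4 (0.20 log units; within the scatter) and the 3-methylphenyl and 4-methylphenyl compounds therefore read alike. Measured against the butyl ester, 4-methylphenyl gives a 5.3-fold higher number from compound 2 to compound 4 (0.72 log units; beyond the scatter) and so stands clear of both low compounds, though nothing at hand explains why the hydroxy and butyl compounds sit low or the methyl compounds higher.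

The compounds shown leave open whether the rise belongs to methyl itself or would follow from any group other than hydroxy at this place, such as methoxy, chlorine or an amine. They also leave open whether a longer chain in place of butyl would read like compound 2 or move toward compound 4.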